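Aryl substituents on the hydrazone of the shared core

The source may report more compounds than this note shows. Statements on the series, on what has been measured and on what is new or still open speak of the compounds shown alone.

Measured compounds in a functional assay on A549 cells (Homo sapiens) for antiproliferative activity, read by MTT assay; a lower number here means a stronger inhibitor, a higher number a weaker inhibitor:
compound 1, `Cn1c(=O)c(=O)n(C2CCCC2)c2nc(N/N=C/c3ccccc3)ncc21`, gives > 100000 nM; this is a limit of the assay, not a number.
compound 2, `Cn1c(=O)c(=O)n(C2CCCC2)c2nc(N/N=C/c3ccc(Cl)cc3)ncc21`, gives 6890 nM.
compound 3, `COc1cccc(/C=N/Nc2ncc3c(n2)n(C2CCCC2)c(=O)c(=O)n3C)c1`, gives 27400 nM.

Compound 1 stands at the limit of this assay, so only a bound is known for it (the limit of > 100000 nM in this assay, at which 1 of the 3 values shown sits). Against that bound, the step of an at least 14-fold lower number from compound 1 to compound 2 (1.16 log units; beyond the scatter) and the step of an at least 3.6-fold lower number from compound 1 to compound 3 (0.56 log units; beyond the scatter) both run downward, the chloro step the larger of the two. Between the two substituted compounds, a 4.0-fold higher number from compound 2 to compound 3 (0.60 log units; beyond the scatter).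

Compound 4, `Cn1c(=O)c(=O)n(C2CCCC2)c2nc(N/N=C/c3cccc(Cl)c3Cl)ncc21`, differs from compound 1 in one place: 2,3-dichlorophenyl in place of phenyl on a carbon with a double bond to nitrogen. Among the measured compounds shown here, of the measured steps, the one from compound 1 to compound 2 bears on it most directly, as a chloro again enters on an aromatic carbon, here twice; the step to compound 3 shows that a second kind of substituent on that ring also lowers the number. A large downward step in this assay is therefore expected for compound 4, most likely of a size similar to or somewhat beyond the chloro step already seen.

Compound 4 is expected to give about 6000 nM in this assay, within a range of 1500 nM to 30000 nM. This estimate corresponds to an expected step of an at least 16-fold lower number from compound 1 to compound 4 (1.22 log units; beyond the scatter).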

Compound 4, half-maximal inhibitory concentration: 39100 nM
Beside the measured number, compound 4's estimate is 6.5-fold (0.81 log units) below it; the whole stated range lies below it.
By their numbers in this assay, from the lowest: compound 2; then compounds 3 and 4 (each within the scatter of the next). At a limit, above all of these: compound 1.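

In this assay, a second chloro on this ring does not take the number further down: 2,3-dichlorophenyl in place of 4-chlorophenyl gives a 5.7-fold higher number from compound 2 to compound 4 (0.75 log units; beyond the scatter), so the count of chloro groups alone does not set the number, and compound 2 stays the lowest of the four. 2,3-Dichlorophenyl in place of 3-methoxyphenyl gives a 1.4-fold higher number from compound 3 to compound 4 (0.15 log units; within the scatter), so these two groups cannot be told apart in this assay, although they are different substituents. Compound 1 has a limit of the assay and not a number, so an at least 2.5-fold lower number from compound 1 to compound 4 (0.40 log units; beyond the scatter) is a bound only, and the chloro and methoxy compounds shown all lie under that limit without a true size for any step from it: the limit of > 100000 nM in this assay, at which 1 of the 4 values shown sits.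

Whether the gap between 4-chlorophenyl and 2,3-dichlorophenyl follows the number of chloro groups or their places on the ring stays open, as the compounds shown do not separate the two. Also open, as far as these compounds go, is how an amine or a carboxylic acid on this ring would read at this position on the carbon with a double bond to nitrogen.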